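A few compounds are considered here, and "the series" means these few. Any claim that something is new, unique, unknown or untested is made for them only; others in the source may bear on it.

Compound 1 `O=C(O)c1csc(-n2nc(-c3ccc(F)cc3)c3ccccc32)n1`: 278 mL/min/kg
Compound 2 `O=C(O)c1csc(-n2nc(C3=CCCC3)c3ccccc32)n1`: 196 mL/min/kg

Among the measured compounds shown here, in an ADME assay (liver) for metabolic stability, with Liver microsome (Rattus norvegicus) as the target, using microsomes (on this read-out higher numbers stand for fast clearance and lower numbers for slow clearance), only two numbers exist so far, and they cannot be told apart. Compound 2 gives 196 mL/min/kg, which lies within the usual scatter of compound 1. For the measured compounds named here, the one measured step, a 1.4-fold lower number from compound 1 to compound 2 (0.15 log units; within the scatter), put cyclopent-1-en-1-yl in place of 4-fluorophenyl on an aromatic carbon.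

Compound 3 `O=C(O)c1csc(-n2nc(N3CCCCC3)c3ccccc32)n1` changes that same place again, with piperidin-1-yl in place of cyclopent-1-en-1-yl on an aromatic carbon. Going by the values given here, no measured compound carries piperidin-1-yl, so the evidence is thin. Among the compounds with values here, the single step at this place is the only guide, and it stayed within the scatter, so no change beyond the scatter is expected in this assay. The expected step is a 1.1-fold higher number from compound 2 to compound 3 (0.03 log units; within the scatter). For compound 3 the estimated clearance is 210 mL/min/kg, with an expected range of 100 mL/min/kg to 400 mL/min/kg.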

Compound 3, clearance: 139 mL/min/kg
Beside the measured number, compound 3's estimate is 1.5-fold (0.18 log units) above it, within the range that was stated.
By their numbers in this assay, from the lowest: compounds 3, 2 and 1 (each within the scatter of the next).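

Piperidin-1-yl is the third kind of group at this place on the five-membered aromatic ring with 2 nitrogen, and the first of the three to carry a nitrogen in its non-aromatic ring. In this assay, the new steps are a 1.4-fold lower number from compound 2 to compound 3 (0.15 log units; within the scatter) and a 2.0-fold lower number from compound 1 to compound 3 (0.30 log units; within the scatter), so 4-fluorophenyl, cyclopent-1-en-1-yl and piperidin-1-yl cannot be told apart here, even though they differ in ring type and atom content. No measurement is available to explain this lack of separation.

On these data alone, it remains open whether a small group such as methyl, or a ring with a second hetero atom such as morpholin-4-yl, would move clearance beyond the scatter. As far as these compounds go, the carboxylic acid on the shared core is the same in all three compounds, so the effect of replacing it with an amide also remains open.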